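A Dimethoxyphenyl Variant in a Weakly Cytotoxic Series

The compounds below may be only part of what the source reports. "The series", "measured", "known", "first", "only" and "open" are said of these compounds alone.

Measured so far:
compound 1, `FC(F)(F)c1ccc(CSc2nc(Nc3ccccc3Cl)c3ccccc3n2)cc1` — > 50000 nM (a limit of the assay, not a number)
compound 2, `CCOc1ccc(Nc2nc(SCc3ccc(C(F)(F)F)cc3)nc3ccccc23)cc1` — 37000 nM

Both were tested in a functional assay on MGC-803 cells (Homo sapiens) for cytotoxicity, read by MTT assay, with a stated time of 72 h; on this read-out higher numbers stand for weaker inhibition and lower numbers for stronger inhibition. Compound 1 gives > 50000 nM, which is a limit of the assay rather than a number, and it sits at the limit of > 50000 nM in this assay, at which 1 of the 2 values shown sits. Compound 2 gives 37000 nM, the only number shown here. Going by the values given here, the single measured step is an at least 1.3-fold lower number from compound 1 to compound 2 (0.13 log units; that floor lies within the scatter), a change of the group on the same nitrogen, and its floor lies within the usual scatter.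

Compound 3, `COc1ccc(Nc2nc(SCc3ccc(C(F)(F)F)cc3)nc3ccccc23)cc1OC`, differs from compound 2 in one place: 3,4-dimethoxyphenyl in place of 4-ethoxyphenyl on a nitrogen on an aromatic ring. Among the compounds with values here, no measured step involves a 3,4-dimethoxyphenyl group, so the only guidance is that the one step seen on this nitrogen, from compound 1 to compound 2, stayed within the scatter. The expected step is therefore none beyond the scatter, and a 1.1-fold lower number from compound 2 to compound 3 (0.02 log units; within the scatter) is the estimate. Compound 3 is estimated at 35000 nM, with a range from 15000 nM to 80000 nM.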

Compound 3, half-maximal inhibitory concentration: 16300 nM
For compound 3 the middle estimate is 2.1-fold (0.33 log units) above the measured one, and the stated range covers the measured number.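

In this assay, going by these compounds alone, the group on this nitrogen now shows an effect that clears the usual scatter: 3,4-dimethoxyphenyl in place of 4-ethoxyphenyl gives a 2.3-fold lower number from compound 2 to compound 3 (0.36 log units; beyond the scatter), whereas the one earlier step at this position could not be told apart from scatter. Set against 2-chlorophenyl, the same 3,4-dimethoxyphenyl group gives an at least 3.0-fold lower number from compound 1 to compound 3 (0.48 log units; beyond the scatter), so the two steps beyond the scatter both lead to the same group. The size of that second step is only a floor, since compound 1 gives a limit of the assay and not a number: the limit of > 50000 nM in this assay, at which 1 of the 3 values shown sits.

The step from 4-ethoxyphenyl to 3,4-dimethoxyphenyl alters the ring in more than one way at once, so the compounds shown cannot separate the effect of the second oxygen-bearing group from that of replacing ethoxy with methoxy; a single 4-methoxyphenyl or 3-methoxyphenyl group on the same nitrogen would bear on this. On these data alone, how an amine, a carboxylic acid or a longer alkoxy chain on that ring would read in this assay also remains open.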